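The source may report more compounds than this note shows. Statements on the series, on what has been measured and on what is new or still open speak of the compounds shown alone.

Measured so far:
Compound 1 `O=c1[nH]/c(=N\OCCCc2cccc([N+](=O)[O-])c2)ccn1[C@@H]1O[C@H](COP(=O)(O)OP(=O)(O)OP(=O)(O)O)[C@@H](O)[C@H]1O` gives 95 nM in a functional assay on 1321-N1 cells for agonist activity at P2Y purinoceptor 4 (Homo sapiens), read by scintillation counting and inositol phosphate accumulation; on this read-out lower numbers stand for an effect already at smaller amounts and higher numbers for an effect only at larger amounts of compound.
Compound 2 `O=c1[nH]/c(=N\OCCCc2cccnc2)ccn1[C@@H]1O[C@H](COP(=O)(O)OP(=O)(O)OP(=O)(O)O)[C@@H](O)[C@H]1O` gives 300 nM in this assay.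

Compound 2 stands at the highest of the two numbers in this assay; its nearest neighbour is compound 1, and the step of a 3.2-fold higher number from compound 1 to compound 2 (0.50 log units; beyond the scatter) lies beyond the scatter and is modest in size. Compound 3 `O=c1[nH]/c(=N\OCCCc2ccc3ccccc3c2)ccn1[C@@H]1O[C@H](COP(=O)(O)OP(=O)(O)OP(=O)(O)O)[C@@H](O)[C@H]1O` is not yet measured. It differs from compound 2 in one place: naphthalen-2-yl in place of pyridin-3-yl on a saturated chain carbon, three bonds along the chain from an oxygen.

For the measured compounds named here, only one measured step bears on this change, and only indirectly. The exchange of 3-nitrophenyl for pyridin-3-yl, seen in a 3.2-fold higher number from compound 1 to compound 2 (0.50 log units; beyond the scatter), raised the number, so the reverse move away from pyridin-3-yl toward a carbon-only aromatic group may well lower it again. Going by the values given here, compound 3 carries two carbon-only rings where compound 2 carried a single ring with one nitrogen, so an expected step of a 2.5-fold lower number from compound 2 to compound 3 (0.40 log units; beyond the scatter) seems reasonable, toward lower numbers and of a size comparable to the one measured step. Compound 3 is therefore expected to give about 120 nM in this assay, within a range from 40 nM to 400 nM.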

Compound 3, half-maximal effective concentration: 128 nM
For compound 3 the middle estimate is 1.1-fold (0.03 log units) below the measured one; the measured number falls inside the stated range.
By their numbers in this assay, from the lowest: compounds 1 and 3 (each within the scatter of the next); then compound 2.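

In this assay, the place on a saturated chain carbon, three bonds along the chain from an oxygen, accepts the larger naphthalen-2-yl, with its 10 heavy atoms and two aromatic rings of carbon only: replacing pyridin-3-yl gives a 2.3-fold lower number from compound 2 to compound 3 (0.37 log units; beyond the scatter). The comparison with the earlier 3-nitrophenyl group gives a 1.3-fold higher number from compound 1 to compound 3 (0.13 log units; within the scatter), so compound 1 and compound 3 cannot be told apart, and two quite different aromatic groups end up at the same level while compound 2 alone stands apart from both. No measurement at hand explains why the pyridin-3-yl group in compound 2 differs from the other two groups.

A plain phenyl group on the same chain would help to show whether the ring nitrogen or the single ring is what separates compound 2 from compound 1 and compound 3. From the compounds shown here alone, it also remains open how this place responds to a longer chain carrying naphthalen-2-yl, or to an amine or a carboxylic acid in place of the aromatic group.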